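The source may report more compounds than this note shows. Statements on the series, on what has been measured and on what is new or still open speak of the compounds shown alone.

Measured compounds in a functional assay on the whole organism (Tail, strain ICR) with Mus musculus as the target, in the tail flick test, with a stated time of 90 min, at a dose of 25 umol/kg by the oral route; on this read-out lower numbers stand for a weaker effect and higher numbers for a stronger effect at the one dose given:
compound 1 `CC(C)[C@H](NC(=O)CN(c1ncnc2c1ncn2C1CCCCO1)C1CC1)C(=O)OCc1ccccc1` — 30.1%
compound 2 `CC[C@H](C)[C@H](NC(=O)CN(c1ncnc2c1ncn2C1CCCCO1)C1CC1)C(=O)OCc1ccccc1` — 22.6%
compound 3 `C[C@H](NC(=O)CN(c1ncnc2c1ncn2C1CCCCO1)C1CC1)C(=O)OCc1ccccc1` — 32.1%

Compound 3 holds the highest of the three numbers, yet the steps of a number 2 percentage points higher from compound 1 to compound 3 (within the scatter) and a number 9.5 percentage points higher from compound 2 to compound 3 (within the scatter) both sit within the scatter, so no ranking among the three can be stated; all three read as the same level of effect.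

Compound 4 `NC(=O)C[C@H](NC(=O)CN(c1ncnc2c1ncn2C1CCCCO1)C1CC1)C(=O)OCc1ccccc1` is the next step. It differs from compound 3 by carbamoyl in place of hydrogen on a saturated chain carbon, two bonds along the chain from an amide-type nitrogen and a carbonyl carbon.

The measured steps all concern the group on the saturated chain carbon bound to the amide-type nitrogen and the carbonyl carbon: a number 7.5 percentage points lower from compound 1 to compound 2 (within the scatter), a number 2 percentage points higher from compound 1 to compound 3 (within the scatter) and a number 9.5 percentage points higher from compound 2 to compound 3 (within the scatter). Each stays within the scatter, so varying that side chain among hydrocarbon groups has moved nothing beyond noise. Going by the values given here, none of them, however, brought in a hydrogen-bond donor or acceptor, so the carbamoyl group has no direct precedent in the set, and the range around any expectation must stay wide.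

On that basis no step beyond the scatter is expected. Compound 4 is estimated to give 29% in this assay, with a range of 15% to 43%. The expected step of a number 3.1 percentage points lower from compound 3 to compound 4 (within the scatter) is estimated to lie within the scatter.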

Compound 4, a percentage reported as activity, at one dose (the size of the read-out at that dose, not a potency): 35%
The estimate for compound 4 lay 6 percentage points below the measured number; measured number inside the range.
By their numbers in this assay, from the lowest: compounds 2, 1, 3 and 4 (each within the scatter of the next, the first and the last beyond it).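

In this assay a side chain carrying a hydrogen-bond donor and acceptor is tolerated at this position: carbamoyl in place of hydrogen, read as methyl to carbamoylmethyl, leaves the effect level with the smaller hydrocarbon side chains (the steps of a number 2.9 percentage points higher from compound 3 to compound 4 (within the scatter) and a number 4.9 percentage points higher from compound 1 to compound 4 (within the scatter)). Set against sec-butyl, the same side chain gives the first step in the series beyond the scatter (a number 12.4 percentage points higher from compound 2 to compound 4 (beyond the scatter)), a modest one, and since compound 1 and compound 3 lie within the scatter of both compound 2 and compound 4, it separates only the two ends of a shallow set and does not establish a trend. Nothing available here explains this difference.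

Still open, going by these compounds, is whether the side chain tolerates an amine, a carboxylic acid or a longer chain such as carbamoylethyl, any of which could show if carbamoylmethyl marks a real gain over sec-butyl or simply sits at the end of the same narrow band. Also open, on these data alone, is how these side chains behave when the benzyl ester is replaced by another ester or by a free carboxylic acid.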